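Adding a Prolyl Ester to a Free Hydroxy Group

The source may report more compounds than this note shows. Statements on the series, on what has been measured and on what is new or still open speak of the compounds shown alone.

Compound 3 `C=C1CC[C@H]2[C@@](C)(CC[C@@H](O)[C@@]2(C)NC=O)[C@@H]1/C=C/C1=CCOC1=O` sits at the edge of what an assay for inhibition of hexokinase-2 (Homo sapiens), read by coupled enzyme assay, with a stated time of 10 min, in the presence of a further agent that is not named here (on this read-out lower numbers stand for stronger inhibition and higher numbers for weaker inhibition), can report. In this assay compound 3 gives > 50000 nM, which is a limit of the assay and not a number. Two related compounds carry an ester on a different part of their shared core: compound 1 `C=C1CC[C@H]2[C@@](C)(CCC(=O)N[C@@]2(C)COC(=O)c2ccccc2)[C@@H]1/C=C/C1=CCOC1=O` and compound 2 `C=C1CC[C@H]2[C@@](C)(CCC(=O)N[C@@]2(C)COC(=O)CCCC[C@@H]2CCSS2)[C@@H]1/C=C/C1=CCOC1=O`. In this assay compound 1 gives > 50000 nM, also a limit. Compound 2 in this assay gives 9360 nM. Among the measured compounds shown here, the one measured step, an at least 5.3-fold lower number from compound 1 to compound 2 (0.72 log units; beyond the scatter), shows that exchanging one ester group for another can carry a compound from the limit of > 50000 nM in this assay, at which 2 of the 3 values shown sit, to a measurable number. Compound 4 `C=C1CC[C@H]2[C@@](C)(CC[C@@H](OC(=O)[C@H]3CCCN3)[C@@]2(C)NC=O)[C@@H]1/C=C/C1=CCOC1=O` differs from compound 3 by (pyrrolidin-2-yl)carbonyl in place of hydrogen on an oxygen on a saturated carbon, so a free hydroxy becomes an ester. For the measured compounds named here, no measured step covers adding an ester where none was; the step from compound 1 to compound 2 shows only that the kind of ester matters. The expectation for compound 4 is therefore a modest gain, an at least 2.5-fold lower number from compound 3 to compound 4 (0.39 log units; beyond the scatter), with much uncertainty. Compound 4 is estimated at 20000 nM, in a range from 4000 nM to 50000 nM.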

Compound 4, half-maximal inhibitory concentration: 26100 nM
Beside the measured number, compound 4's estimate is 1.3-fold (0.12 log units) below it; the measured number falls inside the stated range.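

In this assay, among the compounds shown here, putting an ester on this oxygen gives a compound with a measurable number; the earlier compounds showed only one ester exchanged for another on a different part of the shared core. From the compounds shown here alone, for compound 3, > 50000 nM is a limit and not a number, so the true size of the change remains unknown. What can be read is an at least 1.9-fold lower number from compound 3 to compound 4 (0.28 log units; that floor lies within the scatter), so a real gain is possible, but this floor alone does not establish one.

Going by these compounds, it remains open whether the (pyrrolidin-2-yl)carbonyl group itself matters, or whether a simple acetyl group or a longer carbon chain on the same oxygen would read the same. Also open, on these data alone, is how the ester group of compound 2 would read at this place.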